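This account rests on a few compounds, and the source may have more. Where it says the series, first, only, none or still open, it means among the compounds named here.

For the measured compounds named here, in a functional assay on HCT-116 cells (Homo sapiens) for cytotoxicity, read by trypan blue exclusion, with a stated time of 96 h (a higher number here means a weaker inhibitor of growth, a lower number a stronger inhibitor of growth), compound 1 (`COc1ccc(NS(=O)(=O)/C=C/c2c(OC)cc(OC)cc2OC)cc1`) gives 100 nM and compound 2 (`COc1cc(OC)c(/C=C/S(=O)(=O)Nc2ccc(OC)c(O)c2)c(OC)c1`) gives 10 nM, the lower of the two numbers so far. Compound 3 (`COc1cc(OC)c(/C=C/S(=O)(=O)Nc2ccc(OC)c(N)c2)c(OC)c1`) is the next to be read: amino in place of hydroxy on an aromatic carbon. In words, this is amino in place of hydroxy on an aromatic carbon, ortho to a methoxy group. Going by the values given here, one measured step bears on this place: hydroxy in place of hydrogen gave a 10-fold lower number from compound 1 to compound 2 (1.00 log units; beyond the scatter). Among the compounds with values here, that step shows that a change at this place can move the number beyond the scatter, but no measured compound carries the amino group, so the swap itself remains untested. As compound 3 keeps a substituent there, no step beyond the scatter is expected in this assay, though the uncertainty leans towards a higher number. The expected step is a 1.2-fold higher number from compound 2 to compound 3 (0.08 log units; within the scatter). For compound 3, the estimated value is 12 nM, with an expected range of 4 nM to 50 nM.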

Compound 3, concentration for 50% growth inhibition: 4 nM
Compound 3: the middle estimate sits 3.0-fold (0.48 log units) above what was measured, and the stated range covers the measured number.
By their numbers in this assay, from the lowest: compound 3; then compound 2; then compound 1.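

In this assay amino in place of hydroxy gives a 2.5-fold lower number from compound 2 to compound 3 (0.40 log units; beyond the scatter) and shows that the number at this place depends on which group sits there, not only on whether hydrogen has been replaced. Set against hydrogen, amino gives a 25-fold lower number from compound 1 to compound 3 (1.40 log units; beyond the scatter) as against a 10-fold lower number from compound 1 to compound 2 (1.00 log units; beyond the scatter) for hydroxy. Amino and hydroxy carry the same counts of hydrogen-bond donors and acceptors, so those counts do not separate them, and no measurement at hand accounts for the difference.

Open, on these data alone, is whether a methylamino group, an acetamido group or a hydroxymethyl group at this place would keep the number of compound 3 or lose it. Also open, as far as these compounds go, is whether the same order of the three compounds holds in any other assay.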